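The source may hold more compounds than are shown below. What is called first, only, known or untested is meant among the compounds shown, and "the series" means these compounds.

Measured so far in a functional assay on HepG2 cells (Homo sapiens) for antiproliferative activity, read by fluorescence and resazurin assay, with a stated time of 48 h; a higher number here means a weaker inhibitor, a lower number a stronger inhibitor:
Compound 1 `CCOc1ccc2nc(Cl)c(/C=N/NC(=O)c3cc4cc([N+](=O)[O-])ccc4oc3=O)cc2c1` gives 18100 nM
Compound 2 `CCOc1ccc2nc(Cl)c(/C=N/NC(=O)c3cc4ccccc4oc3=O)cc2c1` gives 33100 nM

Compound 2 stands level with compound 1 within the scatter. Compound 3 `CCOc1ccc2nc(Cl)c(/C=N/NC(=O)c3cc4ccc(O)cc4oc3=O)cc2c1` differs from compound 2 by hydroxy in place of hydrogen on an aromatic carbon with hydroxy in place of hydrogen on an aromatic carbon. Among the compounds with values here, no measured step involves hydroxy. Within the data shown here, the only guide is a 1.8-fold higher number from compound 1 to compound 2 (0.26 log units; within the scatter) for hydrogen in place of nitro on an aromatic carbon, so no step beyond the scatter is expected. The estimated step is a 1.1-fold lower number from compound 2 to compound 3 (0.04 log units; within the scatter) on this reading. For compound 3 the estimate is 30000 nM as the expected value, with an expected range from 13000 nM to 65000 nM around it.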

Compound 3, half-maximal inhibitory concentration: 19200 nM
Compound 3: the middle estimate sits 1.6-fold (0.19 log units) above what was measured, within the range that was stated.
By their numbers in this assay, from the lowest: compounds 1, 3 and 2 (each within the scatter of the next).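

In this assay the first step involving hydroxy, which brings one hydrogen-bond donor and one acceptor onto an aromatic carbon meta to a fused ring and para to a fused ring, is a 1.7-fold lower number from compound 2 to compound 3 (0.24 log units; within the scatter) and so stays level with hydrogen. At this position, then, the change gives no difference that can be read beyond the scatter. No evidence accompanies these compounds that could explain this result.

As far as these compounds go, whether a methoxy group, an amine or a carboxylic acid at this position would behave the same remains open.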